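Urea aryl swap on a quinazoline-linked scaffold

A few compounds are considered here, and "the series" means these few. Any claim that something is new, unique, unknown or untested is made for them only; others in the source may bear on it.

Compound 1 `Cc1ccc(NC(=O)Nc2cccc(CNc3ncnc4ccccc34)c2)cc1` and compound 2 `O=C(Nc1cccc(Cl)c1)Nc1cccc(CNc2ncnc3ccccc23)c1` share a core in which a urea is joined to the rest of the molecule through an amide-type nitrogen. In a functional assay on MGC-803 cells (Homo sapiens) for antiproliferative activity, read by MTT assay (a lower number here means a stronger inhibitor, a higher number a weaker inhibitor), compound 1 gives 31200 nM, the higher of the two numbers recorded, while compound 2 gives 19200 nM. For the measured compounds named here, the only step measured so far, a 1.6-fold lower number from compound 1 to compound 2 (0.21 log units; within the scatter), also replaces the 4-methylphenyl on the amide-type nitrogen, and it stays within the scatter.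

Compound 3 `O=C(Nc1cccc(CNc2ncnc3ccccc23)c1)Nc1cccc(C(F)(F)F)c1` is not yet measured. It differs from compound 1 as follows: 3-(trifluoromethyl)phenyl in place of 4-methylphenyl on an amide-type nitrogen. Going by the values given here, this change sits at the same place as the one step already in hand, so that step is the only guide to it. Since a 1.6-fold lower number from compound 1 to compound 2 (0.21 log units; within the scatter) did not move the number beyond the scatter, no step beyond the scatter is expected for compound 3 either, with at most a slight shift toward a lower number. Compound 3 is therefore expected to give about 22000 nM, with a range from 9000 nM to 55000 nM, which would mean a step of a 1.4-fold lower number from compound 1 to compound 3 (0.15 log units; within the scatter).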

Compound 3, half-maximal inhibitory concentration: > 50000 nM
Compound 3 was reported as a limit; the forecaster's own chance of this, stated with the estimate: 5%; middle value at least 2.2-fold (0.35 log units) away from the limit.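

In this assay compound 3 is reported only as a limit, > 50000 nM, and not as a number. For the compounds shown here, the change from chloro to trifluoromethyl on an aromatic carbon gives an at least 2.6-fold higher number from compound 2 to compound 3 (0.41 log units; beyond the scatter), so this aryl group on the amide-type nitrogen, where the only earlier step had stayed within the scatter, now yields a step beyond it. Read from the 4-methylphenyl compound, the change gives an at least 1.6-fold higher number from compound 1 to compound 3 (0.20 log units; that floor lies within the scatter), a floor that by itself does not separate the two compounds, and the limit is reached by only one of them: the limit of > 50000 nM in this assay, at which 1 of the 3 values shown sits.

With no number for compound 3, the true size of both steps stays open, and these three compounds cannot tell what in the trifluoromethyl group accounts for the step beyond the scatter. Also open, on these data alone, is how this assay would read with a methoxy group, an amine or a carboxylic acid in place of the trifluoromethyl on the same phenyl ring.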